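The source may report more compounds than this note shows. Statements on the series, on what has been measured and on what is new or still open speak of the compounds shown alone.

Working notes on the series. The shared core carries a variable aromatic substituent at one position, and three variants have been measured. Compound 1 `CCC(C)(C)Cc1c[nH]c(CCc2ccc(-n3ncnn3)cc2)n1` gives 89 nM in a functional assay on HEK293 cells for agonist activity at Bombesin receptor subtype-3 (Homo sapiens), read by luminescence and calcium flux, with a stated time of 10 min; a higher number here means that more compound is needed for the effect, a lower number that less compound is needed. Compound 2 `CCC(C)(C)Cc1c[nH]c(CCc2ccc(-n3ccnn3)cc2)n1` gives 93 nM in this assay. Compound 3 `CCC(C)(C)Cc1c[nH]c(CCc2ccc(-c3cccc(C#N)n3)cc2)n1` gives 95 nM in this assay. Compound 3 sits alongside the other two: a 1.1-fold higher number from compound 1 to compound 3 (0.03 log units; within the scatter) and a 1.0-fold higher number from compound 2 to compound 3 (0.01 log units; within the scatter), and likewise a 1.0-fold higher number from compound 1 to compound 2 (0.02 log units; within the scatter).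

Compound 4 `CCC(C)(C)Cc1c[nH]c(CCc2ccc(-c3ccc(F)cn3)cc2)n1` is not yet measured. It differs from compound 3 in one place: 5-fluoropyridin-2-yl in place of 6-cyanopyridin-2-yl on an aromatic carbon. Going by the values given here, the steps that bear on this change are those that exchange the same aromatic substituent on the same carbon, namely from compound 1 to compound 3 and from compound 2 to compound 3, and both stayed within the scatter. With three distinct groups at this position giving numbers that do not separate, no movement beyond the scatter is expected for compound 4 in this assay, so the estimated step is a 1.1-fold higher number from compound 3 to compound 4 (0.02 log units; within the scatter). Compound 4 is therefore estimated at 100 nM, with a range from 45 nM to 220 nM.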

Compound 4, half-maximal effective concentration: 97 nM
Compound 4: the middle estimate sits 1.0-fold (0.01 log units) above what was measured; measured number inside the range.
By their numbers in this assay, from the lowest: compounds 1, 2, 3 and 4 (each within the scatter of the next).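

In this assay the exchange of 6-cyanopyridin-2-yl for 5-fluoropyridin-2-yl leaves the number within the scatter (a 1.0-fold higher number from compound 3 to compound 4 (0.01 log units; within the scatter)), so among the compounds shown the nitrile is not needed to hold the number at this position. The same group also does not separate from 1H-1,2,3-triazol-1-yl (a 1.0-fold higher number from compound 2 to compound 4 (0.02 log units; within the scatter)) or from 2H-tetrazol-2-yl (a 1.1-fold higher number from compound 1 to compound 4 (0.04 log units; within the scatter)), which makes four aromatic groups on this carbon that cannot be told apart in this read-out. Nothing available explains why these exchanges leave the number in place.

As far as these compounds go, all four groups are aromatic rings, so it remains open whether a simple amine, a carboxylic acid or a longer alkyl chain on this carbon would hold the number. From the compounds shown here alone, it is also open whether an unsubstituted phenyl ring would do so.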